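The source may hold more compounds than are shown below. What is called first, only, known or untested is meant among the compounds shown, and "the series" means these compounds.

A small set of closely related compounds was tested in a functional assay on PC-3 cells (Homo sapiens) for cytotoxicity, read by sulforhodamine B assay, with a stated time of 48 h; a higher number here means a weaker inhibitor, a lower number a stronger inhibitor. Compound 1 `CC1=C(/C=C/C(=O)/C=C/c2ccccc2)C(C)(C)CCC1` is the simplest member, and in this assay compound 1 gives 12400 nM. Compound 2 `COc1ccccc1/C=C/C(=O)/C=C/C1=C(C)CCCC1(C)C` differs from compound 1 only by methoxy in place of hydrogen on an aromatic carbon, and in this assay compound 2 gives 14200 nM. The resulting step was a 1.1-fold higher number from compound 1 to compound 2 (0.06 log units; within the scatter), so the methoxy group made no difference that can be told apart from measurement noise.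

Compound 3 `CC1=C(/C=C/C(=O)/C=C/C=C/c2ccccc2)C(C)(C)CCC1` carries a longer linker between the ring and the ketone, and in this assay compound 3 gives 35400 nM. This is the highest of the three numbers, and its distances from compound 2 and from compound 1 both lie beyond the usual scatter, so compound 3 is the weakest inhibitor of the three. The difference between the core of compound 3 and the core of compound 1 is not broken down here.

Compound 4 `COc1ccccc1/C=C/C=C/C(=O)/C=C/C1=C(C)CCCC1(C)C` has not yet been measured. It differs from compound 3 by methoxy in place of hydrogen on an aromatic carbon, the same change that separates compound 2 from compound 1, made at the same kind of place. Because a 1.1-fold higher number from compound 1 to compound 2 (0.06 log units; within the scatter) lay within the scatter, the step of a 1.1-fold higher number from compound 3 to compound 4 (0.03 log units; within the scatter) is expected to be similarly small. Compound 4 is therefore estimated at 38000 nM, with a likely range from 18000 nM to 80000 nM.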

Compound 4, half-maximal inhibitory concentration: 25300 nM
The estimate for compound 4 lay 1.5-fold (0.18 log units) above the measured number; low and high end bracket the measured number.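

The same swap of hydrogen for methoxy on the longer-linked core gives a 1.4-fold lower number from compound 3 to compound 4 (0.15 log units; within the scatter) in this assay, so here too the change cannot be told apart from measurement noise. Set beside the earlier step, the two results agree, and the small step on the core of compound 1 carried over to the core of compound 3: the same change on two cores in this assay, a 1.1-fold higher number (0.06 log units; within the scatter) from compound 1 to compound 2 and a 1.4-fold lower number (0.15 log units; within the scatter) from compound 3 to compound 4, 1.6-fold (0.20 log units) apart, within the scatter of two such steps. This shows only that phenyl to 2-methoxyphenyl, ortho to a large group, left the number within the scatter on these two cores in this one assay; it does not show that methoxy has no effect on other cores, it gives no reason for the result, and two pairs of compounds are too few to set a rule for the whole series.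

The compounds shown leave open whether a different group at this place on the aromatic ring, such as an amine, a carboxylic acid or a longer chain like butoxy, would move the number beyond the scatter on either core. They also leave open whether methoxy would give an equally small step at any other place on that ring.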